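The source may hold more compounds than are shown below. What is called first, only, known or untested is meant among the compounds shown, and "the series" means these compounds.

Measured compounds:
compound 1, `CCOC(=O)c1sc(-c2ccccn2)nc1N1CCC(NCc2ccc(F)cc2)CC1`: 12.6%
compound 2, `CCOC(=O)c1sc(-c2ccccn2)nc1N1CCC(NCc2cccc(C(F)(F)F)c2)CC1`: 19.2%
compound 3, `CCOC(=O)c1sc(-c2ccccn2)nc1N1CCC(NCc2ccc(Cl)cc2Cl)CC1`: 18.6%

All three numbers come from an ADME assay on RAW264.7 cells (Mus musculus) for cytotoxicity, read by MTT assay, with a stated time of 72 h, tested at 50 uM; on this read-out lower numbers stand for less inhibition and higher numbers for more inhibition at the one concentration tested (going by the name of the read-out). The steps of a number 6.6 percentage points higher from compound 1 to compound 2 (within the scatter) and a number 0.6 percentage points lower from compound 2 to compound 3 (within the scatter) both lie within the scatter, as does a number 6 percentage points higher from compound 1 to compound 3 (within the scatter); compound 2 therefore stands together with the other two, and no ordering can be read among them. Each of these steps changes only the group on the saturated chain carbon bound to an amine nitrogen, and none of them moved the read-out beyond the scatter.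

Compound 4, `CCOC(=O)c1sc(-c2ccncc2)nc1N1CCC(NCc2cccc(C(F)(F)F)c2)CC1`, differs from compound 2 by pyridin-4-yl in place of pyridin-2-yl on an aromatic carbon. Among the compounds with values here, no measured step touches this part of the shared core, so nothing in the data speaks directly to the change. What the series does show is a flat read-out across three quite different groups elsewhere on the molecule. On that footing the step of a number 1.2 percentage points lower from compound 2 to compound 4 (within the scatter) is expected to stay within the scatter. Compound 4 is therefore estimated at 18%, with a range from 5% to 32%.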

Compound 4, a percentage reported as inhibition, at one concentration (the size of the read-out at that concentration, not a potency): 14.3%
Compound 4: the middle estimate sits 3.7 percentage points above what was measured; the measured number falls inside the stated range.
By their numbers in this assay, from the lowest: compounds 1, 4, 3 and 2 (each within the scatter of the next).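

In this assay, within the data shown here, the shared core itself changes for the first time: pyridin-4-yl in place of pyridin-2-yl, on the aromatic carbon next to the ring nitrogen and next to the ring sulfur, gives a number 4.9 percentage points lower from compound 2 to compound 4 (within the scatter). The two groups match in heavy atoms, hetero atoms and hydrogen-bond acceptors, so this step isolates the attachment of the pyridine ring, and that change leaves the read-out within the scatter at this position, as the changes on the saturated chain carbon did at theirs. No measurement available here bears on this step, and no explanation can be offered for it.

As far as these compounds go, whether pyridin-3-yl, phenyl or a saturated ring such as piperidine at this carbon would also stay within the scatter remains open. So does the outcome of replacing the ethoxycarbonyl group with a carboxylic acid or an amide.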